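A few compounds are considered here, and "the series" means these few. Any claim that something is new, unique, unknown or untested is made for them only; others in the source may bear on it.

In a functional assay on HepG2 cells (Homo sapiens) for cytotoxicity, read by MTT assay, with a stated time of 72 h (on this read-out lower numbers stand for stronger inhibition and higher numbers for weaker inhibition), compound 1 `COc1cc2ncnc(Nc3ccc(F)c(Cl)c3)c2cc1NC(=O)N/N=C/c1cccc(Br)c1` is recorded as "not active" (no number reported), with no number reported. Compound 2 `COc1cc2ncnc(Nc3ccc(F)c(Cl)c3)c2cc1NC(=O)N/N=C/c1cc(Br)c(O)c(Br)c1`, which shares its core, gives 36800 nM. Among the measured compounds shown here, that is the only number available, so compound 2 cannot be placed against any other measured value, and no step between measured compounds shows how far a change of this kind can move the read-out.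

Compound 3 `COc1cc2ncnc(Nc3ccc(F)c(Cl)c3)c2cc1NC(=O)N/N=C/c1ccc(O)cc1O` has not yet been measured in this assay. It differs from compound 2 in one place: 2,4-dihydroxyphenyl in place of 3,5-dibromo-4-hydroxyphenyl on a carbon with a double bond to nitrogen. In words, this is 2,4-dihydroxyphenyl in place of 3,5-dibromo-4-hydroxyphenyl on a carbon with a double bond to nitrogen.

For the measured compounds named here, the only numerical anchor is compound 2 at 36800 nM, so no step beyond the usual scatter is expected in this assay, and no direction is favoured with any confidence. The expected change is a 1.2-fold lower number from compound 2 to compound 3 (0.09 log units; within the scatter), an estimate that carries wide uncertainty. For compound 3 the estimated value is 30000 nM, with the measurement expected to fall between 10000 nM and 100000 nM.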

Compound 3, half-maximal inhibitory concentration: 32100 nM
The estimate for compound 3 lay 1.1-fold (0.03 log units) below the measured number; low and high end bracket the measured number.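

Placing 2,4-dihydroxyphenyl in place of 3,5-dibromo-4-hydroxyphenyl on a carbon with a double bond to nitrogen gives a 1.1-fold lower number from compound 2 to compound 3 (0.06 log units; within the scatter) in this assay. Among the compounds shown here, this is the first step at this position that can be read as a number, and it shows that the read-out can stay within the scatter even when the two bromine atoms leave and the substitution of the aromatic ring is rearranged, with the ring itself kept and the rest of the structure unchanged. Nothing available accounts for this outcome, so it stands as an observation only.

Compound 1, recorded without a number, gives no readable step to either of the other two compounds, so the place of its 3-bromophenyl group on this scale stays undefined. Also open, going by these compounds, is whether an aromatic ring carrying an amine or a carboxylic acid, or a longer alkyl chain in place of the ring, on the same carbon would move the number beyond the scatter in this assay at all.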